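A few compounds are considered here, and "the series" means these few. Any claim that something is new, unique, unknown or untested is made for them only; others in the source may bear on it.

Working notes on the series. Among the measured compounds shown here, in a functional assay for antagonist activity at melanin-concentrating hormone receptor 1 (Homo sapiens) (a lower number here means a stronger inhibitor, a higher number a weaker inhibitor), compound 3 `CC(C)N(CCN(C(=O)Nc1ccc(F)c(F)c1)C1CC[C@]2(c3cccc(C#N)c3)CC2C1)C(C)C` gives 2.8 nM, which places it second highest of the three numbers so far. Compound 1 `CC(C)N(CCN(C(=O)Nc1cccc([N+](=O)[O-])c1)C1CC[C@]2(c3cccc(C#N)c3)CC2C1)C(C)C` gives 2.7 nM, and compound 2 `CC(C)N(CCN(C(=O)Nc1cccc(Cl)c1)C1CC[C@]2(c3cccc(C#N)c3)CC2C1)C(C)C` gives 6 nM. Compound 4 `CC(C)N(CCN(C(=O)Nc1cc(Cl)nc(Cl)c1)C1CC[C@]2(c3cccc(C#N)c3)CC2C1)C(C)C` differs from compound 3 by 2,6-dichloropyridin-4-yl in place of 3,4-difluorophenyl on an amide-type nitrogen. For the measured compounds named here, the steps that bear on this exchange of the aryl group on the urea nitrogen are a 1.0-fold higher number from compound 1 to compound 3 (0.02 log units; within the scatter) and a 2.1-fold lower number from compound 2 to compound 3 (0.33 log units; beyond the scatter); the former shows no change, the latter a modest shift, while a 2.2-fold higher number from compound 1 to compound 2 (0.35 log units; beyond the scatter) shows that a chloro-bearing ring gave the weakest number in this assay. For compound 4 the expected step is therefore a 2.1-fold higher number from compound 3 to compound 4 (0.33 log units; beyond the scatter), a modest weakening, with wide uncertainty since no pyridine has been measured. Compound 4 is estimated at 6 nM, in the range 2 nM to 18 nM.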

Compound 4, inhibition constant: 2.4 nM
Compound 4: the middle estimate sits 2.5-fold (0.40 log units) above what was measured, within the range that was stated.
By their numbers in this assay, from the lowest: compounds 4, 1 and 3 (each within the scatter of the next); then compound 2.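

On the urea nitrogen in this assay, 2,6-dichloropyridin-4-yl is tolerated: a 1.2-fold lower number from compound 3 to compound 4 (0.07 log units; within the scatter) and a 1.1-fold lower number from compound 1 to compound 4 (0.05 log units; within the scatter) both lie within the scatter, so a ring with a hetero atom and a hydrogen-bond acceptor matches the 3,4-difluorophenyl and 3-nitrophenyl groups. Chlorine on the ring does not by itself go with the higher number of compound 2, as a 2.5-fold lower number from compound 2 to compound 4 (0.40 log units; beyond the scatter) shows beyond the scatter. No measured property is at hand to explain these steps.

The compounds shown leave open what the ring nitrogen contributes apart from the two chlorines, which a 3,5-dichlorophenyl group would separate. As far as these compounds go, whether this nitrogen needs an aromatic ring at all also stays open, a question a cyclohexyl group would address.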